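Naphthyl-for-formylphenyl swap in this series

The source may report more compounds than this note shows. Statements on the series, on what has been measured and on what is new or still open speak of the compounds shown alone.

Values in a functional assay on 786-0 cells (Homo sapiens) for inhibition, read by sulforhodamine B assay, with a stated time of 48 h, tested at 10 uM; a higher number here means more inhibition at the concentration tested (going by the name of the read-out), a lower number less inhibition:
- compound 1 `O=Cc1ccc(-c2cn3ccnc3c(-c3ccc4ncn(C5CCCCC5)c4c3)n2)cc1` gives 46.7%
- compound 2 `c1ccc2c(-c3cn4ccnc4c(-c4ccc5ncn(C6CCCCC6)c5c4)n3)cccc2c1` gives 6.33%
- compound 3 `O=Cc1ccc(-c2cn3ccnc3c(-c3ccc4ncn(Cc5ccccc5)c4c3)n2)cc1` gives 46.7%

Two changes are recorded. The first, (naphthalen-1-yl in place of 4-formylphenyl on an aromatic carbon), gives a number 40.4 percentage points lower from compound 1 to compound 2 (beyond the scatter). The second, (benzyl in place of cyclohexyl on an aromatic nitrogen), gives no change at the digits printed from compound 1 to compound 3 (within the scatter); this is how the cores of compound 1 and compound 3 differ.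

Compound 4 `c1ccc(Cn2cnc3ccc(-c4nc(-c5cccc6ccccc56)cn5ccnc45)cc32)cc1` is not yet measured. It differs from compound 3 by naphthalen-1-yl in place of 4-formylphenyl on an aromatic carbon, which is the same change as made from compound 1 to compound 2, on the same place in both. Because the measured instance gave a number 40.4 percentage points lower from compound 1 to compound 2 (beyond the scatter), and because compound 3 sits level with compound 1 at no change at the digits printed from compound 1 to compound 3 (within the scatter), a comparable downward step is expected: a number 38.7 percentage points lower from compound 3 to compound 4 (beyond the scatter). Compound 4 is therefore estimated at 8%, expected between 0% and 20%. This rests on one measured pair only.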

Compound 4, a percentage reported as inhibition, at one concentration (the size of the read-out at that concentration, not a potency): 12.4%
For compound 4 the middle estimate is 4.4 percentage points below the measured one; measured number inside the range.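

In this assay, naphthalen-1-yl in place of 4-formylphenyl gives a number 34.3 percentage points lower from compound 3 to compound 4 (beyond the scatter) and so carries over from the cyclohexyl core to the benzyl core: the same change on two cores in this assay, a number 40.4 percentage points lower (beyond the scatter) from compound 1 to compound 2 and a number 34.3 percentage points lower (beyond the scatter) from compound 3 to compound 4, 6.1 percentage points apart, within the scatter of two such steps.

Benzyl in place of cyclohexyl gives a number 6.1 percentage points higher from compound 2 to compound 4 (within the scatter) and carries over as well: the same change on two cores in this assay, no change at the digits printed (within the scatter) from compound 1 to compound 3 and a number 6.1 percentage points higher (within the scatter) from compound 2 to compound 4, 6.1 percentage points apart, within the scatter of two such steps.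

This holds for these four compounds only, and the swap removes the formyl group and adds a ring in one step, so the two are not separated and no reason for the drop can be drawn.

Open, on these data alone, is whether the formyl group itself matters, which a plain phenyl, a 4-carboxyphenyl or a 4-aminophenyl at that place would address. Also open, as far as these compounds go, is whether a longer alkyl chain on the aromatic nitrogen sits level with cyclohexyl and benzyl.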